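Sulfonamide series: hydroxyphenyl step from a limit

A few compounds are considered here, and "the series" means these few. Any claim that something is new, unique, unknown or untested is made for them only; others in the source may bear on it.

Compound 2 `COc1ccc(S(=O)(=O)Nc2ccc3oc(-c4ccccc4)nc3c2)cc1` stands only at a limit: in an assay on cells for inhibition of HSP60/HSP10 (Homo sapiens), with a stated time of 60 min (on this read-out lower numbers stand for stronger inhibition and higher numbers for weaker inhibition), compound 2 gives > 100000 nM. Compound 1 `Cc1ccccc1S(=O)(=O)Nc1ccc2oc(-c3ccccc3)nc2c1` is likewise a limit, as in this assay compound 1 gives > 100000 nM. The step that the two limits leave unreadable from compound 1 to compound 2 is therefore not readable in size. Both values rest at the limit of > 100000 nM in this assay, at which 2 of the 2 values shown sit. Compound 3 `O=S(=O)(Nc1ccc2oc(-c3ccccc3)nc2c1)c1ccccc1O` differs from compound 2 by 2-hydroxyphenyl in place of 4-methoxyphenyl on a sulfonyl sulfur. Going by the values given here, no measured step bears on this change, and with both neighbours at the limit no reading beyond a limit is expected, so the step that the limit leaves unreadable from compound 2 to compound 3 is an estimate without support from the series. Compound 3 is expected at 150000 nM, within 30000 nM to 1000000 nM.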

Compound 3, half-maximal inhibitory concentration: 85000 nM
Estimate against measurement, compound 3: 1.8-fold (0.25 log units) above, and the stated range covers the measured number.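

With 2-hydroxyphenyl on the sulfonyl sulfur, the series gives its first reading in this assay that is a number and not a limit. The steps read an at least 1.1-fold lower number from compound 2 to compound 3 (0.07 log units; that floor lies within the scatter) and an at least 1.1-fold lower number from compound 1 to compound 3 (0.07 log units; that floor lies within the scatter), so neither shows a change beyond the scatter. On these data alone, their true size stays unknown, and the step between the two limits cannot be read, because compound 1 and compound 2 both stand at a limit: the limit of > 100000 nM in this assay, at which 2 of the 3 values shown sit.

As far as these compounds go, it remains open whether an amine or a carboxylic acid in place of the hydroxy group would give a step beyond the scatter.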